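This account rests on a few compounds, and the source may have more. Where it says the series, first, only, none or still open, it means among the compounds named here.

The measured compounds in a functional assay on MCF7 cells (Homo sapiens) for antiproliferative activity, read by sulforhodamine B assay, with a stated time of 48 h (on this read-out lower numbers stand for stronger inhibition and higher numbers for weaker inhibition), are:

compound 1, `CCCN1CCN(c2ccc(S(=O)(=O)Oc3ccc(OC)c(OC)c3)cc2)C1=O`, with 6800 nM
compound 2, `CCCN1CCN(c2ccc(S(=O)(=O)Oc3ccc(OC)cc3)cc2)C1=O`, with 20000 nM
compound 3, `CCCCN1CCN(c2ccc(S(=O)(=O)Oc3ccccc3)cc2)C1=O`, with 8800 nM

Among these three, compound 2 sits at the weak end. Compound 1 differs from it by methoxy in place of hydrogen on an aromatic carbon and gives a 2.9-fold lower number from compound 2 to compound 1 (0.47 log units; beyond the scatter), a modest gain. Compound 3 stands closest to compound 1 in this assay, within the usual scatter of it, while its gap to compound 2 lies beyond that scatter; the difference between the core of compound 3 and that of compound 2 is not broken down here.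

Compound 4, `CCCCN1CCN(c2ccc(S(=O)(=O)Oc3ccccc3OC)cc2)C1=O`, has not yet been measured. It is related to compound 3 by methoxy in place of hydrogen on an aromatic carbon. Going by the values given here, this is the same kind of change as the one from compound 2 to compound 1, but not the same: in the earlier pair the entering methoxy sits ortho to a methoxy group and meta to a large group, whereas in compound 4 it sits ortho to a large group. Among the compounds with values here, only one earlier instance of this change is available, so the expectation rests on a single step.

Compound 4 is expected to give 5000 nM in this assay, with a likely range from 2000 nM to 15000 nM. The expected step, a 1.8-fold lower number from compound 3 to compound 4 (0.25 log units; within the scatter), is a modest improvement, because compound 1 showed a 2.9-fold lower number from compound 2 to compound 1 (0.47 log units; beyond the scatter), tempered by the different surroundings of the new group.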

Compound 4, half-maximal inhibitory concentration: 3800 nM
The estimate for compound 4 lay 1.3-fold (0.12 log units) above the measured number; the range from low to high includes it.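

Methoxy in place of hydrogen on an aromatic carbon gave a 2.3-fold lower number from compound 3 to compound 4 (0.36 log units; beyond the scatter) in this assay, a modest gain, and the change carried over to a second core with a step of much the same size as the first: the same change on two cores in this assay, a 2.9-fold lower number (0.47 log units; beyond the scatter) from compound 2 to compound 1 and a 2.3-fold lower number (0.36 log units; beyond the scatter) from compound 3 to compound 4, 1.3-fold (0.10 log units) apart, within the scatter of two such steps. Within these two pairs, then, the gain survives a change of core, and it does so even though the entering methoxy in compound 4 sits ortho to a large group. This does not show why the number falls or that the step would hold on any further core, and since the core and the surroundings of the new group both differ between the pairs, their separate contributions cannot be told apart.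

The compounds shown leave open whether another group on the same aromatic carbon, such as a hydroxyl, a chlorine or an amine, would give a similar step on these cores. They also leave open how the step would fare with a longer chain on the shared core, and whether it would appear at all on a read-out other than this assay.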